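A few compounds are considered here, and "the series" means these few. Any claim that something is new, unique, unknown or untested is made for them only; others in the source may bear on it.

Measured so far: compound 1 `O=C(O[C@H]1C[C@H](n2cc(F)c(=O)[nH]c2=O)O[C@@H]1COP(=O)(O)Oc1cccnc1)c1ccccc1` gives 6.7 h in a physicochemical assay for metabolic stability, read by HPLC, tested at 2 mM; a higher number here means that the compound lasts longer, a lower number that the compound disappears faster; compound 2 `O=C(O[C@H]1C[C@H](n2cc(F)c(=O)[nH]c2=O)O[C@@H]1COP(=O)(O)Oc1ccc2ncccc2c1)c1ccccc1` gives 7.7 h; compound 3 `CCOC(=O)C[n+]1cccc2cc(OP(=O)([O-])OC[C@H]3O[C@@H](n4cc(F)c(=O)[nH]c4=O)C[C@@H]3OC(=O)c3ccccc3)ccc21` gives 2 h.

On these numbers compound 1 stands second highest of three. The nearest number lies one step away, a 1.1-fold higher number from compound 1 to compound 2 (0.06 log units; within the scatter). Among the measured compounds shown here, compound 3 stands furthest from compound 1, beyond the scatter, and no single step links the two. Compound 4 `C[N+]1(C)CCC(OP(=O)([O-])OC[C@H]2O[C@@H](n3cc(F)c(=O)[nH]c3=O)C[C@@H]2OC(=O)c2ccccc2)CC1` is not yet measured. From compound 1 it differs as follows: a group of 12 heavy atoms (7 carbon, 1 nitrogen, 3 oxygen, 1 phosphorus; one six-membered non-aromatic ring with 1 hetero atom) in place of a group of 10 heavy atoms (5 carbon, 1 nitrogen, 3 oxygen, 1 phosphorus; one six-membered aromatic ring with 1 hetero atom), on an oxygen on a saturated carbon. For the measured compounds named here, the one measured step swapped one aromatic ring for another on that oxygen and stayed within the scatter, so it says little about a six-membered non-aromatic ring with 1 hetero atom entering there. Compound 4 is therefore expected near compound 1, with a wide range, as a step of a 1.5-fold lower number from compound 1 to compound 4 (0.17 log units; within the scatter). The estimate for compound 4 is 4.5 h, between 1.5 h and 12 h.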

Compound 4, half-life: > 120 h
Compound 4 ended at the assay's limit; the forecaster's own chance of this, stated with the estimate: 5%; middle value at least 26-fold (1.42 log units) from the limit.
By their numbers in this assay, from the lowest: compound 3; then compounds 1 and 2 (each within the scatter of the next). At a limit, above all of these: compound 4.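

In this assay, the group on this oxygen turns out to matter greatly: the swap of one aromatic ring for another stayed within the scatter, whereas the six-membered non-aromatic ring with 1 hetero atom gives an at least 17-fold higher number from compound 1 to compound 4 (1.25 log units; beyond the scatter). Compound 4 stands at a limit and not at a number: the limit of > 120 h in this assay, at which 1 of the 4 values shown sits.

Only compound 4 carries a non-aromatic ring in this place, so this one step cannot separate the loss of the aromatic ring from the other differences between the groups. From the compounds shown here alone, whether an open-chain amine or a plain alkyl chain on that oxygen would reach the same limit stays open.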